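Removing the imidazolylmethyl group on a second core

The source may hold more compounds than are shown below. What is called first, only, known or untested is meant among the compounds shown, and "the series" means these compounds.

Four compounds share one core, in which an ester-bearing ring system carries an amide on one side and an amine on the other. Compound 1 `CCOC(=O)c1sc2ccc(NCc3nc[nH]c3C)cc2c1NC(=O)c1ccccc1` is the parent; in a functional assay on HeLa cells (Homo sapiens) for antiproliferative activity, read by MTT assay, with a stated time of 48 h (a lower number here means a stronger inhibitor of growth, a higher number a weaker inhibitor of growth), compound 1 gives 23300 nM. Compound 2 `CCOC(=O)c1sc2ccc(NCc3nc[nH]c3C)cc2c1NC(=O)c1cc(OC)c(OC)c(OC)c1` differs from compound 1 in one place, (3,4,5-trimethoxyphenyl in place of phenyl on a carbonyl carbon), and in this assay compound 2 gives 2230 nM, which is a 10-fold lower number from compound 1 to compound 2 (1.02 log units; beyond the scatter). Compound 3 `CCOC(=O)c1sc2ccc(N)cc2c1NC(=O)c1ccccc1` is compound 1 stripped of the group on the amine, (hydrogen in place of (5-methyl-1H-imidazol-4-yl)methyl on a nitrogen on an aromatic ring). For compound 3 this assay reports only a limit, > 50000 nM. The step is therefore an at least 2.1-fold higher number from compound 1 to compound 3 (0.33 log units; beyond the scatter), with the true size hidden by the limit of > 50000 nM in this assay, at which 1 of the 3 values shown sits.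

Compound 4 `CCOC(=O)c1sc2ccc(N)cc2c1NC(=O)c1cc(OC)c(OC)c(OC)c1` carries the same change on the core of compound 2, (hydrogen in place of (5-methyl-1H-imidazol-4-yl)methyl on a nitrogen on an aromatic ring); the place is identical to that in compound 3, so the two steps are the same change on cores that differ as described for compound 2. The step from compound 2 to compound 4 is expected to resemble the step from compound 1 to compound 3, an at least 2.1-fold higher number from compound 1 to compound 3 (0.33 log units; beyond the scatter), so a weakening is estimated, a 4.0-fold higher number from compound 2 to compound 4 (0.61 log units; beyond the scatter). In this assay compound 4 is expected to give about 9000 nM, most likely between 3000 nM and 35000 nM.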

Compound 4, concentration for 50% growth inhibition: 4660 nM
For compound 4 the middle estimate is 1.9-fold (0.29 log units) above the measured one, within the range that was stated.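

In this assay, taking the (5-methyl-1H-imidazol-4-yl)methyl group off the amine also weakens growth inhibition on the second core, with a 2.1-fold higher number from compound 2 to compound 4 (0.32 log units; beyond the scatter). The change therefore acts in the same direction on both cores, and the two steps can be set side by side: the same change on two cores in this assay, an at least 2.1-fold higher number (0.33 log units; beyond the scatter) from compound 1 to compound 3 and a 2.1-fold higher number (0.32 log units; beyond the scatter) from compound 2 to compound 4; the limit leaves it open whether they differ. Whether the step has the same size on both cores is not shown, since the first step ends in a limit for compound 3: the limit of > 50000 nM in this assay, at which 1 of the 4 values shown sits.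

The compounds shown leave open whether the imidazole ring itself matters, or whether a simple group on the same nitrogen, such as methyl or benzyl, would give the same result as the (5-methyl-1H-imidazol-4-yl)methyl group. They also leave open how the change behaves when the carbonyl carbon carries a different group, such as cyclohexyl.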